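From Benzoyl Ester to Vinyl Ester on a Shared Core

The compounds below may be only part of what the source reports. "The series", "measured", "known", "first", "only" and "open" are said of these compounds alone.

Of the compounds shown here, three built on one shared core have been tested in an ADME assay on Vero cells (Chlorocebus sabaeus) for cytotoxicity, read by MTT assay, with a stated time of 48 h; on this read-out higher numbers stand for weaker inhibition and lower numbers for stronger inhibition. Compound 1, `O=C(OC1CCC(CN2CCN(c3cc(=O)c4cc(C(F)(F)F)cc([N+](=O)[O-])c4s3)CC2)CC1)c1ccccc1`, carries a benzoyloxy group on a saturated ring carbon. In this assay compound 1 gives > 64 ug/mL, which is a limit of the assay and not a number. Compound 2, `CS(=O)(=O)OC1CCC(CN2CCN(c3cc(=O)c4cc(C(F)(F)F)cc([N+](=O)[O-])c4s3)CC2)CC1`, shows > 64 ug/mL in this assay, again a limit. Compound 3, `O=C(NC1CCC(CN2CCN(c3cc(=O)c4cc(C(F)(F)F)cc([N+](=O)[O-])c4s3)CC2)CC1)c1ccccc1`, gives 44.3 ug/mL in this assay, a measured number. Between the first two, a step that the two limits leave unreadable from compound 1 to compound 2. The other two steps, an at least 1.4-fold lower number from compound 1 to compound 3 (0.15 log units; that floor lies within the scatter) and an at least 1.4-fold lower number from compound 2 to compound 3 (0.15 log units; that floor lies within the scatter), are each only a floor, and that floor lies within the scatter.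

Compound 4, `C=CC(=O)OC1CCC(CN2CCN(c3cc(=O)c4cc(C(F)(F)F)cc([N+](=O)[O-])c4s3)CC2)CC1`, differs from compound 1 by vinyl in place of phenyl on a carbonyl carbon. For the measured compounds named here, none of the measured steps touches the carbonyl carbon itself: they exchange the whole group on the ring oxygen or replace the ester by an amide, so no step bears directly on this change. What the data do show is the limit of > 64 ug/mL in this assay, at which 2 of the 3 values shown sit, and compound 1 stands at that limit. Compound 4 is therefore expected to give 70 ug/mL in this assay, estimated between 40 ug/mL and 130 ug/mL. The expected step that the limit leaves unreadable from compound 1 to compound 4 is estimated to be none beyond the scatter.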

Compound 4, half-maximal inhibitory concentration: > 64 ug/mL
Compound 4: a limit, no number (the forecaster's own chance of this, stated with the estimate: 60%); the middle value lies beyond the limit too.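

In this assay compound 4 gives > 64 ug/mL, a limit of the assay and not a number. For the compounds shown here, with either phenyl or vinyl on the carbonyl carbon, the ester stays beyond the measured range, so removing the aromatic ring from this spot brings no measured number into view, and only compound 3, the amide, goes against this shared result: the limit of > 64 ug/mL in this assay, at which 3 of the 4 values shown sit. The steps from compound 1 and from compound 2 to compound 4 cannot be read, with limits at both ends, and the one step that can be read, an at least 1.4-fold higher number from compound 3 to compound 4 (0.15 log units; that floor lies within the scatter), gives only a floor.

On these data alone, how far compound 1 and compound 4 lie past the limit remains unknown, so a real difference between phenyl and vinyl could be hidden there. Also open, as far as these compounds go, is whether a longer chain such as propyl, or an amine such as aminomethyl, on the carbonyl carbon would give a measured number in this assay, and whether vinyl would behave the same way on the amide of compound 3.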